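The source may report more compounds than this note shows. Statements on the series, on what has been measured and on what is new or still open speak of the compounds shown alone.

Of the compounds shown here, two of a shared core have been measured in a physicochemical assay for solubility, read by HPLC, using the shake flask method, measured as kinetic solubility, with a stated time of 2 h, at pH 7.4; on this read-out higher numbers stand for higher solubility and lower numbers for lower solubility. Compound 1, `Cc1cc(NCc2ccccn2)n2ncc(-c3c(C)cccc3C)c2n1`, returns only a limit of the assay in this assay: compound 1 gives < 5000 nM. Compound 2, `Cc1cc(NCc2ccccn2)n2ncc(-c3ccc(C(=O)Nc4ccccc4)cc3)c2n1`, gives 5000 nM in this assay, and this is the only number shown. The other value shown is a limit of the assay, as noted in the limit of < 5000 nM in this assay, at which 1 of the 2 values shown sits. For the measured compounds named here, no step between two measured compounds is given here, so no measured size of change is available.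

Compound 3, `Cc1cc(NCc2ccccn2)n2ncc(-c3ccc(O)cc3)c2n1`, is yet to be measured in this assay. It differs from compound 2 by hydroxy in place of phenylcarbamoyl on an aromatic carbon. Going by the values given here, with no measured step to rest on, compound 3 is expected to show an upward move, estimated as a 4.0-fold higher number from compound 2 to compound 3 (0.60 log units; beyond the scatter), beyond the usual scatter. Compound 3 is therefore estimated at 20000 nM in this assay, within a range from 5000 nM to 80000 nM.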

Compound 3, solubility: 10900 nM
Compound 3: the middle estimate sits 1.8-fold (0.26 log units) above what was measured; low and high end bracket the measured number.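

Hydroxy in place of phenylcarbamoyl on an aromatic carbon gives a 2.2-fold higher number from compound 2 to compound 3 (0.34 log units; beyond the scatter), the first measured size of change at this position in this assay, even though the group leaving and the group entering hold the same count of hydrogen-bond donors and acceptors. 4-Hydroxyphenyl in place of 2,6-dimethylphenyl gives an at least 2.1-fold higher number from compound 1 to compound 3 (0.33 log units; beyond the scatter), a second comparison at the same place on the shared core. Compound 1 gives a limit of the assay, so that second step is a bound and not an exact size: the limit of < 5000 nM in this assay, at which 1 of the 3 values shown sits.

The compounds shown do not separate the effect of the entering hydroxy from that of the leaving phenylcarbamoyl. They also leave open how an amine, a carboxylic acid or a methoxy group at this place would read in this assay.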